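The compounds below may be only part of what the source reports. "The series", "measured", "known", "first", "only" and "open" are said of these compounds alone.

Compound 1, `CC(=O)N1CCc2nc(C)c(C(OC(C)(C)C)C(=O)O)c(-c3ccc(C)cc3)c2C1`, in an ADME assay on MT2 cells (Homo sapiens) for cytotoxicity, read by XTT assay, with a stated time of 4 days (on this read-out lower numbers stand for higher toxicity in this test and higher numbers for lower toxicity in this test), gives > 40000 nM, which is a limit of the assay.
Compound 2, `Cc1ccc(-c2c3c(nc(C)c2[C@H](OC(C)(C)C)C(=O)O)CCN(CCCc2ccccc2)C3)cc1`, in this assay gives > 40000 nM, again a limit.
Compound 3, `Cc1ccc(-c2c3c(nc(C)c2[C@H](OC(C)(C)C)C(=O)O)CCN(C(=O)NCc2ccccc2)C3)cc1`, in this assay gives > 40000 nM, once more a limit and not a number.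

Compound 3 therefore stands where every other value in this set stands: at the limit of > 40000 nM in this assay, at which 3 of the 3 values shown sit. Nothing within the shown data separates it from compound 1 or compound 2. Among the measured compounds shown here, the one change between neighbours, a step that the two limits leave unreadable from compound 2 to compound 3, cannot be read, since both ends of it are limits.

Compound 4 is `Cc1ccc(-c2c3c(nc(C)c2[C@H](OC(C)(C)C)C(=O)O)CCN(C(=O)OCc2ccccc2)C3)cc1`. It differs from compound 3 in one place: benzyloxy in place of benzylamino on a carbonyl carbon. For the measured compounds named here, no measured step bears on this change, and the only neighbouring step, from compound 2 to compound 3, is itself unreadable. Three compounds with three different substituents on the ring nitrogen all sit at the limit, so the change to compound 4 is expected to move nothing that the assay could register.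

Compound 4 is accordingly expected to sit at or beyond the limit again, with an estimate of 50000 nM and a range from 30000 nM to 150000 nM. The step this implies, a step that the limit leaves unreadable from compound 3 to compound 4, is expected to be nothing beyond the scatter, and most probably only a limit will be reported.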

Compound 4, half-maximal cytotoxic concentration: > 40000 nM
Compound 4 ended at the assay's limit (the forecaster's own chance of this, stated with the estimate: 85%); the middle value does not contradict the limit.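

The steps linking compound 2, compound 3 and compound 4 cannot be read, since each of these compounds gives only a limit and not a number: the limit of > 40000 nM in this assay, at which 4 of the 4 values shown sit.

What the compounds shown leave open is whether any of these groups on the ring nitrogen of the shared core changes the half-maximal cytotoxic concentration at all.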